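The source may hold more compounds than are shown below. What is called first, only, known or untested is meant among the compounds shown, and "the series" means these compounds.

Measured so far in a functional assay on SK-MEL-5 cells (Homo sapiens) for inhibition, read by sulforhodamine B assay, with a stated time of 48 h; a higher number here means that more compound is tolerated, a lower number that less compound is tolerated:
compound 1 `Nc1cc(N)c2nc(-c3ccccc3)c(NCc3ccc(Cl)c(Cl)c3)nc2c1` gives 34700 nM
compound 2 `Nc1cc(N)c2nc(-c3ccccc3)c(Oc3ccc(F)cc3)nc2c1` gives 83200 nM
compound 3 `CCOC(=O)[C@H](CCC(=O)O)NC(=O)c1ccc(Oc2nc3cc(N)cc(N)c3nc2-c2ccccc2)cc1` gives only a limit, < 100000 nM

Of the two plain numbers, compound 2 holds the highest value in this assay, so more of it is tolerated than of compound 1; the gap from compound 1 up to compound 2 lies beyond the usual scatter of repeated measurements. Within the data shown here, the value for compound 3 is a limit of this assay and not a number, so it offers no step for comparison. Among the measured compounds shown here, no step between measured compounds that differ in one place is available here, so the size of any single change on the shared core is unknown from these three.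

The next compound is compound 4 `COc1ccc(Sc2nc3cc(N)cc(N)c3nc2-c2ccccc2)cc1`. It differs from compound 2 in one place:
(4-methoxyphenyl)sulfanyl in place of 4-fluorophenoxy on an aromatic carbon

For the measured compounds named here, with no measured step of this kind to draw on, the change is expected to move this assay little, if at all, beyond the scatter, in either direction. Compound 4 is therefore expected to give about 60000 nM, within a range from 25000 nM to 100000 nM. The step this expectation implies, a 1.4-fold lower number from compound 2 to compound 4 (0.14 log units; within the scatter), is estimated to sit within the scatter; whether it does is what the measurement will settle.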

Compound 4, concentration lethal to 50% of the cells: < 100000 nM
Compound 4 gave a limit, no number; the forecaster's own chance of this, stated with the estimate: 25%; the middle value is on the limit's open side.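

In this assay, among these compounds, compound 4 gives < 100000 nM as a limit of the assay and not a number, so no step from compound 2 to compound 4 can be read. The compounds shown leave open how far (4-methoxyphenyl)sulfanyl in place of 4-fluorophenoxy on an aromatic carbon of the shared core moves the lethal concentration, and in which direction.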